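Swapping a Hydrazide Amino Group for Benzyl

The source may report more compounds than this note shows. Statements on the series, on what has been measured and on what is new or still open speak of the compounds shown alone.

The two measured compounds share one core, a ring system that carries an amine and a carbonyl-linked chain; they differ only in the size of the saturated ring fused to it. Compound 1 `NNC(=O)c1c(N)sc2c1CCCCC2` was tested in a functional assay on CHO cells for agonist activity at adenosine receptor A1 (Homo sapiens), read by ERK phosphorylation, tested at 3 uM (a higher number here means a stronger effect of the compound at the concentration tested, a lower number a weaker effect), and gives 52%. Compound 2 `NNC(=O)c1c(N)sc2c1CCCCCC2` carries one more carbon in its saturated ring, and in this assay compound 2 gives 48%. The two numbers lie within the usual scatter of each other, so nothing separates compound 1 from compound 2 on this reading.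

Compound 3 `Nc1sc2c(c1C(=O)NCc1ccccc1)CCCCCC2` has not been measured. It keeps the saturated ring of compound 2 and changes the chain on the carbonyl: benzyl in place of amino on an amide-type nitrogen. For the measured compounds named here, no measured pair shows such a change, so its effect is unknown here. Both measured compounds hold the amino group, and nothing tells whether the benzyl group will keep, raise or lower the response. The best guess is that the step from compound 2 to compound 3 stays within the scatter, expected as a number 8 percentage points lower from compound 2 to compound 3 (within the scatter), with a wide spread. Compound 3 is therefore expected to give about 40% in this assay, somewhere between 10% and 75%.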

Compound 3, a percentage reported as activity, at one concentration (the size of the read-out at that concentration, not a potency): 48%
The estimate for compound 3 lay 8 percentage points below the measured number; the range from low to high includes it.
By their numbers in this assay, from the lowest: compounds 2, 3 and 1 (each within the scatter of the next).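

In this assay, for the compounds shown here, the swap of amino for benzyl on the amide-type nitrogen gives no change at the digits printed from compound 2 to compound 3 (within the scatter), and this is the first view of this position, since the earlier pair differed only in the saturated ring. At this single test concentration, the position accepts a much larger group: benzyl brings 7 heavy atoms and a six-membered aromatic ring where amino had 1 heavy atom, and it has 0 hydrogen-bond donors and 0 hydrogen-bond acceptors where amino had one of each, yet the response holds. Nothing measured here explains why the response holds.

Going by these compounds, whether the same result would come from a methyl group, a phenyl ring directly on the amide-type nitrogen, or a longer phenethyl chain remains open, as does whether benzyl would behave the same way on the saturated ring of compound 1. Each number is also a read-out at one concentration, so these compounds could still give a stronger or weaker effect at other concentrations, and a full concentration series would be needed to show this.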